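This account rests on a few compounds, and the source may have more. Where it says the series, first, only, none or still open, it means among the compounds named here.

Working notes on the series. In a functional assay on A549 cells (Homo sapiens) for antiproliferative activity, read by MTT assay (on this read-out higher numbers stand for weaker inhibition and lower numbers for stronger inhibition), compound 1 (`COc1cc2c(Oc3ccc(NC(=O)Nc4cccc(C)c4)cc3)ccnc2cc1OCCCCCCC(=O)NO`) gives 2010 nM, compound 2 (`COc1cc2c(Oc3ccc(NC(=O)Nc4ccccc4C(F)(F)F)cc3)ccnc2cc1OCCCCCCC(=O)NO`) gives 5280 nM, and compound 3 (`COc1cc2c(Oc3ccc(NC(=O)Nc4ccc(C(F)(F)F)cc4Cl)cc3)ccnc2cc1OCCCCCCC(=O)NO`) gives 970 nM, the lowest of the three numbers. Compound 4 (`COc1ccccc1NC(=O)Nc1ccc(Oc2ccnc3cc(OCCCCCCC(=O)NO)c(OC)cc23)cc1`) carries 2-methoxyphenyl in place of 2-chloro-4-(trifluoromethyl)phenyl on an amide-type nitrogen. All measured steps change the group at this same place. They are modest but beyond the scatter: a 2.6-fold higher number from compound 1 to compound 2 (0.42 log units; beyond the scatter), a 2.1-fold lower number from compound 1 to compound 3 (0.32 log units; beyond the scatter) and a 5.4-fold lower number from compound 2 to compound 3 (0.74 log units; beyond the scatter). Neither replacement measured so far matches compound 3 at 970 nM, so a modest move toward weaker inhibition is expected in this assay. The expected change is a 2.7-fold higher number from compound 3 to compound 4 (0.43 log units; beyond the scatter). For compound 4 the estimate is 2600 nM, with an expected range of 1100 nM to 6000 nM.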

Compound 4, half-maximal inhibitory concentration: 16200 nM
The estimate for compound 4 lay 6.2-fold (0.79 log units) below the measured number, and the stated range ends below it.
By their numbers in this assay, from the lowest: compound 3; then compound 1; then compound 2; then compound 4.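

In this assay 2-methoxyphenyl on the amide-type nitrogen gives the largest step seen at this place, a 17-fold higher number from compound 3 to compound 4 (1.22 log units; beyond the scatter), and compound 4 also has the highest number of the series, with an 8.1-fold higher number from compound 1 to compound 4 (0.91 log units; beyond the scatter) and a 3.1-fold higher number from compound 2 to compound 4 (0.49 log units; beyond the scatter). The last step shows that, with the rest of compound 2 unchanged, methoxy in place of trifluoromethyl on the aromatic carbon is enough to weaken inhibition beyond the scatter. No measured evidence bears on the origin of these steps. Open, going by these compounds, is how an amine or a carboxylic acid on this phenyl ring would compare with methoxy.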